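Shortening a Chain on Two Related Cores

A few compounds are considered here, and "the series" means these few. Any claim that something is new, unique, unknown or untested is made for them only; others in the source may bear on it.

Compound 2 `N=C(S)CCCCCn1nc(-c2ccccc2)ccc1=O` and compound 1 `N=C(S)CCCn1nc(-c2ccccc2)ccc1=O` share one core. In a functional assay on the whole organism (stomach) for inhibition, with Rattus norvegicus as the target, at a dose of 100 mg/kg by the intraduodenal route (a higher number here means more inhibition at the dose given (going by the name of the read-out), a lower number less inhibition), compound 2 gives 91.4% and compound 1 gives 75.6%. The change between them is a group of 3 heavy atoms (1 carbon, 1 nitrogen, 1 sulfur; no ring) in place of a group of 5 heavy atoms (3 carbon, 1 nitrogen, 1 sulfur; no ring), on a saturated chain carbon, three bonds along the chain from an aromatic nitrogen, and it made a step of a number 15.8 percentage points lower from compound 2 to compound 1 (beyond the scatter). Compound 3 `N=C(S)CCCCN1N=C(c2ccccc2)CCC1=O` rests on a different core; how its core differs from that of compound 2 is not broken down here. In this assay compound 3 gives 50.2%, the lowest of the three measured numbers. Compound 4 `N=C(S)CCN1N=C(c2ccccc2)CCC1=O` is not yet measured. It arises from compound 3 by the same kind of change, (a group of 3 heavy atoms (1 carbon, 1 nitrogen, 1 sulfur; no ring) in place of a group of 5 heavy atoms (3 carbon, 1 nitrogen, 1 sulfur; no ring), on a saturated chain carbon, two bonds along the chain from an amide-type nitrogen in a ring); the place differs, being two bonds along the chain from an amide-type nitrogen in a ring rather than three bonds along the chain from an aromatic nitrogen. The step of a number 15.8 percentage points lower from compound 2 to compound 1 (beyond the scatter) is the only one of this kind seen so far. For compound 4 a step of about that size, a number 15.2 percentage points lower from compound 3 to compound 4 (beyond the scatter), is expected, though the core and the place differ. Compound 4 is therefore estimated at 35%, expected to fall between 15% and 55%.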

Compound 4, a percentage reported as inhibition, in the whole organism at one dose (the size of the read-out at that dose, not a potency): 38.2%
Beside the measured number, compound 4's estimate is 3.2 percentage points below it; low and high end bracket the measured number.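

On the core of compound 3, the same shortening of the chain gives in this assay a number 12 percentage points lower from compound 3 to compound 4 (beyond the scatter) and can be set beside the earlier step: the same change on two cores in this assay, a number 15.8 percentage points lower (beyond the scatter) from compound 2 to compound 1 and a number 12 percentage points lower (beyond the scatter) from compound 3 to compound 4, 3.8 percentage points apart, within the scatter of two such steps. In these two pairs, the change therefore carried from one core to the other in the same direction and at a comparable size. Going by these compounds alone, that rests on only two pairs, whose changes also sit in different places, so it shows neither a general rule for this series nor why the number falls, and a read-out at one dose is not a potency.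

Open, going by these compounds, is whether the step holds on a third core or with a longer chain. Also open, on these data alone, is how an amine or a carboxylic acid in place of the chain's end group would read in this assay.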